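Pentyl for tert-Butyl on the Anilino-Linked Sulfonylurea

The source may hold more compounds than are shown below. What is called first, only, known or untested is meant among the compounds shown, and "the series" means these compounds.

Measured compounds:
compound 1, `Cc1cccc(Oc2ccc(C#N)cc2S(=O)(=O)NC(=O)NC(C)(C)C)c1`: 690 nM
compound 2, `CCCCCNC(=O)NS(=O)(=O)c1cc(C#N)ccc1Oc1cccc(C)c1`: 680 nM
compound 3, `Cc1ccccc1Nc1ccc(C#N)cc1S(=O)(=O)NC(=O)NC(C)(C)C`: 4780 nM

All three were tested in a functional assay on HEK293 cells for antagonist activity at thromboxane A2 receptor (Homo sapiens), read by fluorescence and calcium flux; a lower number here means a stronger inhibitor, a higher number a weaker inhibitor. Compound 2 differs from compound 1 by pentyl in place of tert-butyl on an amide-type nitrogen, and this gave a 1.0-fold lower number from compound 1 to compound 2 (0.01 log units; within the scatter). Compound 3 differs from compound 1 in its core, by (2-methylphenyl)amino in place of 3-methylphenoxy on an aromatic carbon, and this gave a 6.9-fold higher number from compound 1 to compound 3 (0.84 log units; beyond the scatter), so compound 3 carries the highest number of the three.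

Compound 4, `CCCCCNC(=O)NS(=O)(=O)c1cc(C#N)ccc1Nc1ccccc1C`, has not yet been measured. It differs from compound 3 by pentyl in place of tert-butyl on an amide-type nitrogen, the same change that separates compound 2 from compound 1, at the same place with the same neighbours. Because that change gave a 1.0-fold lower number from compound 1 to compound 2 (0.01 log units; within the scatter), a step within the scatter, the estimate for compound 4 in this assay is 4500 nM. The expected range for compound 4 runs from 1800 nM to 11000 nM. For the measured compounds named here, this expectation corresponds to a step of a 1.1-fold lower number from compound 3 to compound 4 (0.03 log units; within the scatter), an essentially flat move resting on the single earlier pairing alone, with no second pair on a different core to confirm it.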

Compound 4, half-maximal inhibitory concentration: 7850 nM
The estimate for compound 4 lay 1.7-fold (0.24 log units) below the measured number; measured number inside the range.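

In this assay, pentyl in place of tert-butyl on the amide-type nitrogen gave a 1.6-fold higher number from compound 3 to compound 4 (0.22 log units; within the scatter), and this step on the second core agrees with the earlier one: the same change on two cores in this assay, a 1.0-fold lower number (0.01 log units; within the scatter) from compound 1 to compound 2 and a 1.6-fold higher number (0.22 log units; within the scatter) from compound 3 to compound 4, 1.7-fold (0.22 log units) apart, within the scatter of two such steps. The change of core, (2-methylphenyl)amino in place of 3-methylphenoxy, gave a 12-fold higher number from compound 2 to compound 4 (1.06 log units; beyond the scatter) with pentyl on the nitrogen, and it too carried over from the tert-butyl pair: the same change on two cores in this assay, a 6.9-fold higher number (0.84 log units; beyond the scatter) from compound 1 to compound 3 and a 12-fold higher number (1.06 log units; beyond the scatter) from compound 2 to compound 4, 1.7-fold (0.22 log units) apart, within the scatter of two such steps. Within these four compounds the two changes therefore read as independent of each other, but this rests on a single pair of chains and a single pair of cores, and it does not show that either change would carry over to any other core.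

The core change alters both the linking atom and the place of the methyl group, so these compounds cannot say which of the two accounts for the step. Going by these compounds, a (3-methylphenyl)amino or 2-methylphenoxy group would separate them, and a longer chain such as heptyl or a cyclohexyl group on the nitrogen remains open.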